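The source may hold more compounds than are shown below. What is called first, only, known or untested is meant among the compounds shown, and "the series" means these compounds.

Going by the values given here, compound 1 `C/C=C\C#Cc1ccc(CCC(=O)O)c(F)c1` is one of only two compounds measured so far. In a functional assay on 1321-N1 cells for agonist activity at Free fatty acid receptor 1 (Homo sapiens), read by calcium flux, with a stated time of 0.4 s (on this read-out lower numbers stand for smaller maximal responses and higher numbers for larger maximal responses), compound 1 gives 91%, and compound 2 `O=C(O)CCc1ccc(C#CC2CCCCC2)cc1` gives 98%, a gap that lies within the usual scatter, so the two sit together near a full response. Compound 3 `C/C=C(\C)C#Cc1ccc(CCC(=O)O)c(F)c1` has not been measured; it differs from compound 1 in one place: 1-methylprop-1-en-1-yl in place of prop-1-en-1-yl on a triple-bonded carbon. Among the compounds with values here, no measured pair shows what such a change does to the largest response. Since compound 1 and compound 2 both reach nearly the full response, the step of a number 1 percentage points lower from compound 1 to compound 3 (within the scatter) is expected to be small, no larger than the scatter. Compound 3 is therefore expected to give 90%, within a range from 75% to 105%.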

Compound 3, largest response reached (reported as efficacy), in percent of the reference or control that the assay uses: 97%
Compound 3: middle estimate off by 7 percentage points, on the low side; measured number inside the range.
By their numbers in this assay, from the lowest: compounds 1, 3 and 2 (each within the scatter of the next).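

In this assay, having 1-methylprop-1-en-1-yl in place of prop-1-en-1-yl on a triple-bonded carbon gives a number 6 percentage points higher from compound 1 to compound 3 (within the scatter). This first measured one-place pair shows that, at this position, the largest response does not separate these two groups, and both compounds stay close to a full response. No measurement here accounts for this result. Whether an amine or a hydroxyl group at this position would also give a response close to full remains open, since all the groups shown there contain only carbon and hydrogen.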